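Adding chloro to the benzylsulfanyl group of compound 2

The compounds below may be only part of what the source reports. "The series", "measured", "known", "first", "only" and "open" are said of these compounds alone.

Compound 2 `CC1=C(C(=O)Nc2ccc(F)cc2)C(c2ccc([N+](=O)[O-])cc2)N=C(SCc2ccccc2)N1` gives 21% in a functional assay on the whole organism (artery, strain albino) with Rattus norvegicus as the target, with a stated time of 900 min, at a dose of 10 mg/kg by the oral route (on this read-out lower numbers stand for less inhibition and higher numbers for more inhibition at the one dose given (going by the name of the read-out)), the higher of the two numbers measured. Compound 1 `COc1ccc(C2N=C(SCc3ccccc3)NC(C)=C2C(=O)Nc2ccc(F)cc2)cc1OC` gives 1% in this assay. For the measured compounds named here, the only recorded step, a number 20 percentage points higher from compound 1 to compound 2 (beyond the scatter), changed the aryl group on the saturated ring carbon and leaves the benzylsulfanyl group untouched. Compound 3 `CC1=C(C(=O)Nc2ccc(F)cc2)C(c2ccc([N+](=O)[O-])cc2)N=C(SCc2cccc(Cl)c2)N1` differs from compound 2 by chloro in place of hydrogen on an aromatic carbon. Going by the values given here, no measured step bears on this change, so compound 3 is expected to stay close to compound 2, with a step of a number 3 percentage points higher from compound 2 to compound 3 (within the scatter), within the scatter. The estimate for compound 3 is 24%, between 5% and 45%.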

Compound 3, a percentage reported as inhibition, in the whole organism at one dose (the size of the read-out at that dose, not a potency): 10.8%
Estimate against measurement, compound 3: 13.2 percentage points above; the range from low to high includes it.
By their numbers in this assay, from the lowest: compounds 1 and 3 (each within the scatter of the next); then compound 2.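

The benzylsulfanyl group, untouched by the earlier step, proves to matter in this assay: chloro in place of hydrogen gives a number 10.2 percentage points lower from compound 2 to compound 3 (beyond the scatter). Substitution on this aromatic carbon therefore does not leave the inhibition at the one dose given unchanged, and here it lowers it. Nothing shown explains this drop.

The compounds shown carry only hydrogen and chloro at this place, so it stays open whether the loss is particular to chloro. A methoxy group or an amine on the same carbon would test that, and chloro elsewhere on this ring would test the place itself.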